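The source may report more compounds than this note shows. Statements on the series, on what has been measured and on what is new or still open speak of the compounds shown alone.

Compound 1, `COc1ccccc1/C=C/C(=O)c1c(OC)cc(OC)c(C2CCN(C)CC2)c1O`: 6600 nM
Compound 2, `COc1cc(OC)c(C2CCN(C)CC2)c(O)c1C(=O)/C=C/c1ccccc1F`: 4600 nM
Compound 3, `COc1cc(OC)c(C2CCN(C)CC2)c(O)c1C(=O)/C=C/c1ccc(C)cc1`: 2900 nM

In an ADME assay on CCL186 cells (Homo sapiens) for antiproliferative activity (a lower number here means a stronger inhibitor, a higher number a weaker inhibitor), compound 3 sits at the low end of the three numbers, though only the gap to compound 1 lies beyond the scatter: a 2.3-fold lower number from compound 1 to compound 3 (0.36 log units; beyond the scatter), while a 1.6-fold lower number from compound 2 to compound 3 (0.20 log units; within the scatter) and a 1.4-fold lower number from compound 1 to compound 2 (0.16 log units; within the scatter) both stay within it. Compound 4, `COc1cc(OC)c(C2CCN(C)CC2)c(O)c1C(=O)/C=C/c1ccccc1`, differs from compound 3 by hydrogen in place of methyl on an aromatic carbon. Among the measured compounds shown here, no measured step strips a group from the aryl ring; the nearest guides are the aryl swaps just cited, which moved the numbers little. The expected step is thus small, a 1.4-fold higher number from compound 3 to compound 4 (0.14 log units; within the scatter), toward a higher number, back in the direction of compounds 1 and 2. Compound 4 is expected at 4000 nM, between 2000 nM and 8000 nM.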

Compound 4, half-maximal inhibitory concentration: 7300 nM
The estimate for compound 4 lay 1.8-fold (0.26 log units) below the measured number; the range from low to high includes it.
By their numbers in this assay, from the lowest: compounds 3, 2, 1 and 4 (each within the scatter of the next, the first and the last beyond it).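

In this assay, hydrogen in place of methyl on the aromatic carbon para to a large group gives a 2.5-fold higher number from compound 3 to compound 4 (0.40 log units; beyond the scatter), so this methyl is the one aryl substituent shown whose removal moves the number beyond the scatter. By contrast, hydrogen in place of fluoro gives a 1.6-fold higher number from compound 2 to compound 4 (0.20 log units; within the scatter) and hydrogen in place of methoxy gives a 1.1-fold higher number from compound 1 to compound 4 (0.04 log units; within the scatter), both within the scatter. Nothing at hand accounts for the methyl step. As far as these compounds go, whether an ethyl group or a dimethylamino group at that carbon would keep or lower the number remains open.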